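Trimming an Amide Cyclopropyl in a Piperidine Series

This account rests on a few compounds, and the source may have more. Where it says the series, first, only, none or still open, it means among the compounds named here.

Compound 1 `Cn1ncc(Cl)c1-c1cc(C(=O)N[C@@H]2CN[C@H](CC(=O)NC3CC3)C[C@H]2c2ccc(Cl)c(Cl)c2)oc1Cl` is one of three related compounds measured in a functional assay on HCT-116 cells (Homo sapiens) for antiproliferative activity, read by sulforhodamine B assay, with a stated time of 72 h (on this read-out higher numbers stand for weaker inhibition and lower numbers for stronger inhibition), where compound 1 gives 740 nM. Its number sits alongside those of compound 2 `CC(=O)NCC[C@@H]1C[C@@H](c2ccc(F)c(F)c2)[C@H](NC(=O)c2cc(-c3c(Cl)cnn3C)c(Cl)o2)CN1`, which gives 920 nM, and compound 3 `CC(=O)OCC[C@@H]1C[C@@H](c2ccc(F)c(F)c2)[C@H](NC(=O)c2cc(-c3c(Cl)cnn3C)c(Cl)o2)CN1`, which gives 690 nM, the three lying within the usual scatter of one another. Compound 4 `Cn1ncc(Cl)c1-c1cc(C(=O)N[C@@H]2CN[C@H](CC(N)=O)C[C@H]2c2ccc(Cl)c(Cl)c2)oc1Cl` differs from compound 1 by hydrogen in place of cyclopropyl on an amide-type nitrogen. Within the data shown here, the only single-change step measured, a 1.3-fold lower number from compound 2 to compound 3 (0.12 log units; within the scatter), alters a side-chain terminal group rather than an amide nitrogen, so no measured step speaks directly to this change. Compound 4 is therefore expected to show a 1.2-fold higher number from compound 1 to compound 4 (0.09 log units; within the scatter), nothing beyond the scatter. For compound 4 the estimate is 900 nM, with a range of 400 nM to 2000 nM.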

Compound 4, half-maximal inhibitory concentration: 650 nM
Compound 4: middle estimate off by 1.4-fold (0.14 log units), on the high side; the range from low to high includes it.
By their numbers in this assay, from the lowest: compounds 4, 3, 1 and 2 (each within the scatter of the next).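

In this assay, among these compounds, the first direct reading at this amide-type nitrogen, hydrogen in place of cyclopropyl (a 1.1-fold lower number from compound 1 to compound 4 (0.06 log units; within the scatter)), stays within the scatter. On this pair, the cyclopropyl is therefore not needed to hold the antiproliferative read-out, and the carbamoylmethyl chain of compound 4 serves as well as the (cyclopropylcarbamoyl)methyl chain of compound 1. Nothing available explains this result. Still open, as far as these compounds go, is whether a methyl, an isopropyl or a phenyl on this nitrogen would also stay within the scatter. Also open, from the compounds shown here alone, is how a carboxylic acid or an amine would read in place of the carbamoyl group.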